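A few compounds are considered here, and "the series" means these few. Any claim that something is new, unique, unknown or untested is made for them only; others in the source may bear on it.

Compound 1 `Cc1cccc(NC(=O)COc2ccc3cc(/C=C4/SC(=O)NC4=O)ccc3c2)n1` gives 7500 nM in an assay on isolated protein for inhibition of histone deacetylase 8 (Homo sapiens), with a stated time of 1 h (a lower number here means a stronger inhibitor, a higher number a weaker inhibitor), the higher of the two numbers recorded there. Compound 2 `Cc1cc(Br)ccc1NC(=O)COc1ccc2cc(/C=C3/SC(=O)NC3=O)ccc2c1` gives 7400 nM in this assay, and the step of a 1.0-fold lower number from compound 1 to compound 2 (0.01 log units; within the scatter) lies within the scatter. The unmeasured compound 3 `O=C(COc1ccc2cc(/C=C3/SC(=O)NC3=O)ccc2c1)Nc1ccc(F)cc1F` differs from compound 1 by 2,4-difluorophenyl in place of 6-methylpyridin-2-yl on an amide-type nitrogen. Among the compounds with values here, only the step from compound 1 to compound 2 bears on this change, since it also replaces the group on the amide-type nitrogen, and it was a 1.0-fold lower number from compound 1 to compound 2 (0.01 log units; within the scatter), so no step beyond the scatter is expected. Compound 3 is therefore estimated at 7500 nM, in the range 3500 nM to 16000 nM, a step of no change at the digits printed from compound 1 to compound 3 (within the scatter) expected.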

Compound 3, half-maximal inhibitory concentration: > 50000 nM
Compound 3: only a limit was reported; the forecaster's own chance of this, stated with the estimate: 10%; at least 6.6-fold (0.82 log units) between middle value and limit.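

In this assay, the group on the amide-type nitrogen is not free to change: 2,4-difluorophenyl brings an at least 6.6-fold higher number from compound 1 to compound 3 (0.82 log units; beyond the scatter) and an at least 6.7-fold higher number from compound 2 to compound 3 (0.82 log units; beyond the scatter). The earlier exchange of 6-methylpyridin-2-yl for 4-bromo-2-methylphenyl stayed within the scatter, so this position's sensitivity to the group only now appears.

Going by these compounds, the full size of both steps stays open because the value of compound 3 is a limit, not a number: the limit of > 50000 nM in this assay, at which 1 of the 3 values shown sits. On these data alone, whether a plain phenyl, a 4-fluorophenyl or a 2-methylphenyl here would stay close to compound 1 also remains open.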